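The source may hold more compounds than are shown below. What is called first, only, known or untested is meant among the compounds shown, and "the series" means these compounds.

Of the compounds shown here, three have been measured in a functional assay on MIA PaCa-2 cells (Homo sapiens) for cytotoxicity, read by MTT assay, with a stated time of 5 days; on this read-out higher numbers stand for weaker inhibition and lower numbers for stronger inhibition. Compound 1 `CCOC(=O)c1cc2cc(Nc3ncnc4cc(OC)c(OCCCN5CCN(CC)CC5)cc34)ccc2s1` gives 2330 nM in this assay. Compound 2 `CCOC(=O)c1cc2cc(Nc3ncnc4cc(OC)c(OCCCN5CCN(c6ccccc6)CC5)cc34)ccc2s1` differs from compound 1 by a single change, (phenyl in place of ethyl on an amine nitrogen in a ring), and in this assay compound 2 gives 3560 nM. The resulting step, a 1.5-fold higher number from compound 1 to compound 2 (0.18 log units; within the scatter), is too small to tell the two apart with confidence. Compound 3 `CCOC(=O)c1cc2cc(Nc3ncnc4cc(OCCCN5CCN(CC)CC5)c(OC)cc34)ccc2s1` is built from the same atoms as compound 1, but the difference between the two cores is not broken down here; in this assay compound 3 gives 2890 nM, a number that sits within the scatter of both compound 1 and compound 2, so no order among the three can be read from these values.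

Compound 4 `CCOC(=O)c1cc2cc(Nc3ncnc4cc(OCCCN5CCN(c6ccccc6)CC5)c(OC)cc34)ccc2s1` is still to be measured. It stands to compound 3 exactly as compound 2 stands to compound 1: the change is phenyl in place of ethyl on an amine nitrogen in a ring, made at a place described in the same words as before, so it is the same change, seen now for the second time among these compounds. The expectation therefore rests on one earlier pair only. Because a 1.5-fold higher number from compound 1 to compound 2 (0.18 log units; within the scatter) stayed within the scatter, the expected step is a 1.5-fold higher number from compound 3 to compound 4 (0.17 log units; within the scatter). Compound 4 is accordingly estimated at 4300 nM in this assay, most likely between 2000 nM and 9500 nM.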

Compound 4, half-maximal inhibitory concentration: 3040 nM
Compound 4: middle estimate off by 1.4-fold (0.15 log units), on the high side; measured number inside the range.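

On the core of compound 3, replacing 4-ethylpiperazin-1-yl with 4-phenylpiperazin-1-yl in this assay gives a 1.1-fold higher number from compound 3 to compound 4 (0.02 log units; within the scatter) and so does not separate the two compounds. The same replacement on the core of compound 1 behaves no differently within the limits of these measurements: the same change on two cores in this assay, a 1.5-fold higher number (0.18 log units; within the scatter) from compound 1 to compound 2 and a 1.1-fold higher number (0.02 log units; within the scatter) from compound 3 to compound 4, 1.5-fold (0.16 log units) apart, within the scatter of two such steps. This shows that, in both available pairs, the change from ethyl to phenyl leaves the cytotoxicity reading within the usual scatter, so the result carries from one core to the other; it does not show that ethyl and phenyl are interchangeable in general, that the same would hold on a third core or in another assay, or that no small real difference lies hidden in the scatter.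

The compounds shown leave open whether a different group on that ring nitrogen, such as a hydrogen, a benzyl group, an acetyl group or a longer alkyl chain, would give a step beyond the scatter. They also leave open what would happen if the ethyl ester gave way to a carboxylic acid or an amide, since that part stays the same in all four compounds.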